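Methylphenyl Replaces Pyridyl on the Sulfonyl Sulfur

A few compounds are considered here, and "the series" means these few. Any claim that something is new, unique, unknown or untested is made for them only; others in the source may bear on it.

Three measured compounds share one core and differ only in the group attached to the sulfonyl sulfur. In an assay on MDA-MB-231 cells for binding affinity to C-X-C chemokine receptor type 4 (Homo sapiens), read by fluorescence and microscopy, with stated times of 10 min and 30 min (a lower number here means that less compound is needed, a higher number that more compound is needed for the effect), compound 1 `CCN(CC)Cc1ccc(S(=O)(=O)NCc2ccc(CNC(=O)c3ccc(F)cc3)cc2)cc1` gives 1 nM, compound 2 `O=C(NCc1ccc(CNS(=O)(=O)c2ccc3c(c2)CCO3)cc1)c1ccc(F)cc1` gives 10 nM, and compound 3 `O=C(NCc1ccc(CNS(=O)(=O)c2cccnc2)cc1)c1ccc(F)cc1` gives 1000 nM. Compound 3 therefore stands highest of the three numbers; its nearest neighbour is compound 2 and its furthest is compound 1, both beyond the scatter. Among the measured compounds shown here, the only single-point step among the measured compounds is a 100-fold higher number from compound 2 to compound 3 (2.00 log units; beyond the scatter), in which a six-membered aromatic ring with 1 hetero atom took the place of a group containing a six-membered aromatic ring of carbon only.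

Compound 4 `Cc1ccccc1S(=O)(=O)NCc1ccc(CNC(=O)c2ccc(F)cc2)cc1` carries 2-methylphenyl in place of pyridin-3-yl on a sulfonyl sulfur. This change runs in the opposite sense to that step: the ring with 1 hetero atom leaves and a six-membered aromatic ring of carbon only enters, although 2-methylphenyl is smaller than the group of compound 2 and lacks its five-membered non-aromatic ring. Because a 100-fold higher number from compound 2 to compound 3 (2.00 log units; beyond the scatter) was large, a step toward a lower number is expected for compound 4, though probably not a full reversal. Compound 4 is accordingly estimated at 50 nM, with a range from 10 nM to 300 nM, which corresponds to an expected 20-fold lower number from compound 3 to compound 4 (1.30 log units; beyond the scatter).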

Compound 4, effective concentration (reported as EC, without a stated level of effect): 100 nM
Compound 4: middle estimate off by 2.0-fold (0.30 log units), on the low side; the measured number falls inside the stated range.
By their numbers in this assay, from the lowest: compound 1; then compound 2; then compound 4; then compound 3.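

Placing 2-methylphenyl in place of pyridin-3-yl on the sulfonyl sulfur gives a 10-fold lower number from compound 3 to compound 4 (1.00 log units; beyond the scatter), so in this assay a six-membered aromatic ring of carbon only lowers the number here even without the five-membered non-aromatic ring that compound 2 carries. That ring swap accounts for only part of the larger gap seen in a 100-fold higher number from compound 2 to compound 3 (2.00 log units; beyond the scatter), for a 10-fold higher number from compound 2 to compound 4 (1.00 log units; beyond the scatter) remains, and the two new steps therefore place compound 4 in the middle of that gap, with the group of compound 2 still giving the lower number. No measurement is at hand that would explain either step, and the numbers alone record the size of each change without saying what lies behind it.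

The compounds shown leave open how much of the change belongs to the ring itself and how much to its methyl group, as plain phenyl and 2-ethylphenyl are not among them. Among the compounds shown here, they also leave open how a group carrying an amine other than the one in compound 1, such as piperidin-1-ylmethyl, or a carboxylic acid would read on the same sulfonyl sulfur.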